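Shortening the Tether Between Urea and Anilide

The source may hold more compounds than are shown below. What is called first, only, known or untested is meant among the compounds shown, and "the series" means these compounds.

Compound 1, `CCOc1cc(C(C)(C)C)ccc1C1=NC(c2ccc(Cl)cc2)C(c2ccc(Cl)cc2)N1C(=O)NCCCCCCCC(=O)Nc1ccccc1N`, was tested in an assay on isolated protein for inhibition of E3 ubiquitin-protein ligase Mdm2 (Homo sapiens), read by fluorescence polarization, with a stated time of 30 min (a lower number here means a stronger inhibitor, a higher number a weaker inhibitor), where compound 1 gives 1020 nM. Two companions share its core. Compound 2, `CCOc1cc(C(C)(C)C)ccc1C1=NC(c2ccc(Cl)cc2)C(c2ccc(Cl)cc2)N1C(=O)N1CCN(c2ncc(C(=O)NO)cn2)CC1`, gives 1050 nM in this assay, a number within the scatter of compound 1, so the two cannot be told apart. Compound 3, `CCOc1cc(C(C)(C)C)ccc1C1=NC(c2ccc(Cl)cc2)C(c2ccc(Cl)cc2)N1C(=O)N1CCN(CCCCCCCC(=O)NO)CC1`, gives 290 nM, the lowest of the three numbers and beyond the scatter from compound 1, which therefore stands second highest of the three. Among the measured compounds shown here, the single measured step, a 3.6-fold lower number from compound 2 to compound 3 (0.56 log units; beyond the scatter), exchanges the group on an amine nitrogen in a ring and leaves the rest untouched.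

Compound 4, `CCOc1cc(C(C)(C)C)ccc1C1=NC(c2ccc(Cl)cc2)C(c2ccc(Cl)cc2)N1C(=O)NCCCCCC(=O)Nc1ccccc1N`, differs from compound 1 by (2-aminophenyl)carbamoyl in place of 2-((2-aminophenyl)carbamoyl)ethyl on a saturated chain carbon, five bonds along the chain from an amide-type nitrogen: the tether to the aminophenyl amide is shortened while both ends are kept. For the measured compounds named here, no measured step tests such a shortening, and the one step available concerns a different part of the molecule, so it offers no direct guide. With no evidence either way, the change is expected to give a 1.0-fold lower number from compound 1 to compound 4 (0.01 log units; within the scatter), nothing beyond the scatter. Compound 4 is therefore estimated at 1000 nM, with a range from 400 nM to 2500 nM.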

Compound 4, inhibition constant: 1430 nM
Estimate against measurement, compound 4: 1.4-fold (0.16 log units) below; measured number inside the range.
By their numbers in this assay, from the lowest: compound 3; then compounds 1, 2 and 4 (each within the scatter of the next).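

In this assay, the change at this saturated chain carbon gives a 1.4-fold higher number from compound 1 to compound 4 (0.15 log units; within the scatter), so compound 1 and compound 4 cannot be told apart. The earlier step concerned only the group on an amine nitrogen in a ring, whereas this one shows that, across this one pair, altering the tether with both of its ends kept leaves a difference no larger than the scatter. No separate measurement bears on why these two tether lengths cannot be told apart.

From the compounds shown here alone, a single pair cannot show how far this tolerance extends, so a longer chain than that of compound 1 or a shorter one than that of compound 4 remains open. Also open, going by these compounds, is how a carboxylic acid in place of the (2-aminophenyl)carbamoyl end would read on this tether.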